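Chloro in place of hydrogen on the anilino acid series

The compounds below may be only part of what the source reports. "The series", "measured", "known", "first", "only" and "open" are said of these compounds alone.

In a functional assay on A549 cells (Homo sapiens) for cytotoxicity, read by MTT assay, with a stated time of 72 h (a higher number here means a weaker inhibitor, a lower number a stronger inhibitor), compound 3 `Cc1oc2ncnc(Nc3ccccc3)c2c1C(=O)O` gives 191000 nM, the highest of the two numeric values in the series. The other numeric value belongs to compound 1 `Cc1oc2ncnc(Nc3cccc(Br)c3)c2c1C(=O)O`, which gives 43000 nM. Compound 2 `Cc1oc2ncnc(Nc3cccc(Cl)c3)c2c1C(=O)NC(C)C` is recorded only as a limit, > 1000000 nM, so it gives no number to compare.

The next compound is compound 4 `Cc1oc2ncnc(Nc3cccc(Cl)c3)c2c1C(=O)O`, which keeps the acid of compound 3 and adds one substituent. The change is chloro in place of hydrogen on an aromatic carbon.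

For the measured compounds named here, only one measured step bears on this position. It is a 4.4-fold higher number from compound 1 to compound 3 (0.65 log units; beyond the scatter), with hydrogen in place of bromo on an aromatic carbon. Read in reverse, that step suggests a halogen on this ring lowers the number in this assay, though a single pair establishes no pattern. Chloro is not bromo, so the bromo step serves only as a guide to direction and rough size. A modest drop of similar or somewhat smaller size is therefore expected, and the expected change is a 2.9-fold lower number from compound 3 to compound 4 (0.47 log units; beyond the scatter). For compound 4 the estimated value is 65000 nM, with an expected range of 28000 nM to 150000 nM.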

Compound 4, half-maximal inhibitory concentration: 95500 nM
Estimate against measurement, compound 4: 1.5-fold (0.17 log units) below; low and high end bracket the measured number.
By their numbers in this assay, from the lowest: compound 1; then compounds 4 and 3 (each within the scatter of the next). At a limit, above all of these: compound 2.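

In this assay, chloro in place of hydrogen on the anilino acid gives a 2.0-fold lower number from compound 3 to compound 4 (0.30 log units; within the scatter), so at this position chloro does not move the number clear of the scatter, unlike the bromo step read earlier. The two halogens do not read alike here: chloro in place of bromo gives a 2.2-fold higher number from compound 1 to compound 4 (0.35 log units; beyond the scatter), which leaves bromo as the only substituent in the acid series with a step beyond the scatter from the unsubstituted anilino compound. Hydroxy in place of isopropylamino on the carbonyl carbon, with the 3-chlorophenyl group held constant, gives an at least 10-fold lower number from compound 2 to compound 4 (1.01 log units; beyond the scatter), the one large step in the set, though compound 2 is only a limit and so the true size stays unknown: the limit of > 1000000 nM in this assay, at which 1 of the 4 values shown sits.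

As far as these compounds go, whether fluoro or methoxy at this position would read closer to chloro or to bromo remains open. Also open, from the compounds shown here alone, is how a methyl ester or a primary amide on the carbonyl carbon would compare with the acid, since this change rests on a single pair with one end at a limit.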